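From methylamino to ethylsulfanyl: one swap, little guidance

This account rests on a few compounds, and the source may have more. Where it says the series, first, only, none or still open, it means among the compounds named here.

Compound 1 `CNc1nc(C)c(-c2ccnc(Nc3ccc(OC)cc3OC)n2)s1`: 300 nM
Compound 2 `COc1ccc(Nc2nccc(-c3cn(C(C)C)c4ccccc34)n2)c(OC)c1`: 3250 nM
Compound 3 `CCCn1cc(-c2ccnc(Nc3ccc(OC)cc3OC)n2)c2ccccc21`: 3620 nM

All three values come from a functional assay on MV4-11 cells (Homo sapiens) for inhibition, read by resazurin assay, with a stated time of 72 h; a higher number here means a weaker inhibitor of growth, a lower number a stronger inhibitor of growth. Compound 1 has the lowest number of the three, beyond the scatter from both others, so it is the strongest inhibitor of growth in this small set. Compound 4 `CCSc1nc(C)c(-c2ccnc(Nc3ccc(OC)cc3OC)n2)s1` keeps the core of compound 1 and changes one group, with ethylsulfanyl in place of methylamino on an aromatic carbon.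

Going by the values given here, the only measured step, a 1.1-fold higher number from compound 2 to compound 3 (0.05 log units; within the scatter), puts propyl in place of isopropyl on an aromatic nitrogen. Among the compounds with values here, it involves neither of the groups exchanged here, so it offers little guidance, and no measured pair tests this swap. Compound 1 already stands lowest at 300 nM, so a moderate move to a higher number in this assay seems the likelier outcome, though this is uncertain. The expected change is a 2.7-fold higher number from compound 1 to compound 4 (0.43 log units; beyond the scatter). For compound 4 the estimated value is 800 nM, with an expected range from 200 nM to 3500 nM.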

Compound 4, concentration for 50% growth inhibition: 32400 nM
Beside the measured number, compound 4's estimate is 41-fold (1.61 log units) below it; the whole stated range lies below it.
By their numbers in this assay, from the lowest: compound 1; then compounds 2 and 3 (each within the scatter of the next); then compound 4.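

In this assay, this position proves highly sensitive: on the aromatic carbon next to the ring nitrogen and next to the ring sulfur, ethylsulfanyl in place of methylamino gives a 110-fold higher number from compound 1 to compound 4 (2.03 log units; beyond the scatter) and so a far weaker inhibitor of growth. The earlier compounds shown here differ only in a group on an aromatic nitrogen and could not show that a single exchange on this carbon can have so large an effect. Nothing available here explains the loss.

The compounds shown do not separate the exchange of nitrogen for sulfur from the added carbon in the chain, so the contribution of each remains open. Ethylamino or methylsulfanyl at this place would separate the two, while a plain amine would extend the comparison to a group with no carbon chain.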